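Working notes: acetyl for hydrogen on the aromatic amine

This account rests on a few compounds, and the source may have more. Where it says the series, first, only, none or still open, it means among the compounds named here.

Compound 1 `Cc1cc(C#N)cc(C)c1Oc1ccnc(Nc2ccc(C#N)cc2)n1` gives 1.39 in a physicochemical assay for lipophilicity; a higher number here means a more lipophilic compound, a lower number a more polar compound.
Compound 2 `Cc1cc(C#N)cc(C)c1Oc1nc(Nc2ccc(C#N)cc2)ncc1[N+](=O)[O-]` gives 0.7 in this assay.
Compound 3 `Cc1cc(C#N)cc(C)c1Oc1nc(Nc2ccc(C#N)cc2)ncc1N` gives -0.21 in this assay.

Compound 3 stands lowest of the three numbers, with a number 0.91 log units lower from compound 2 to compound 3 (beyond the scatter) and a number 1.60 log units lower from compound 1 to compound 3 (beyond the scatter), both beyond the scatter; the remaining step is a number 0.69 log units lower from compound 1 to compound 2 (beyond the scatter). Compound 4 `CC(=O)Nc1cnc(Nc2ccc(C#N)cc2)nc1Oc1c(C)cc(C#N)cc1C` carries acetyl in place of hydrogen on a nitrogen on an aromatic ring. For the measured compounds named here, no measured pair covers this change; the two steps into compound 3 show only that the amino compound sits lowest in this assay. Capping that amino with an acetyl is expected to give a small rise or no step beyond the scatter, estimated as a number 0.31 log units higher from compound 3 to compound 4 (beyond the scatter). Compound 4 is therefore estimated at 0.1, with a range from -0.4 to 0.6.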

Compound 4, partition coefficient: -0.38
The estimate for compound 4 lay 0.48 log units above the measured number; low and high end bracket the measured number.
By their numbers in this assay, from the lowest: compounds 4 and 3 (each within the scatter of the next); then compound 2; then compound 1.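

In this assay, acetyl in place of hydrogen on this nitrogen gives no step beyond the scatter (a number 0.17 log units lower from compound 3 to compound 4 (within the scatter)), so the amino and acetamido compounds cannot be told apart here. The acetamido compound still stands apart from the nitro compound (a number 1.08 log units lower from compound 2 to compound 4 (beyond the scatter)) and from the compound with hydrogen on that aromatic carbon (a number 1.77 log units lower from compound 1 to compound 4 (beyond the scatter)). Nothing available accounts for these steps.

Open, going by these compounds, is whether a longer acyl chain, such as butyryl, would also stay within the scatter of compound 3. On these data alone, a methanesulfonyl or dimethylamino group on this position also remains untested in these data.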